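A Cyclopentyl Tail in Place of a Hydroxylated Chain

A few compounds are considered here, and "the series" means these few. Any claim that something is new, unique, unknown or untested is made for them only; others in the source may bear on it.

compound 1 `CCCCCCCCCCCCS(=O)(=O)/C=C/c1ccc(O)c(O)c1`: 8500 nM
compound 2 `O=S(=O)(/C=C/c1ccc(O)c(O)c1)CCCCCCCCO`: 6700 nM
compound 3 `CC(C)(C)OC(=O)N1CCCC1CS(=O)(=O)/C=C/c1ccc(O)c(O)c1`: 7100 nM

In a functional assay, read by fluorescence and spectrophotometry, with a stated time of 1 h (a lower number here means that less compound is needed, a higher number that more compound is needed for the effect), compound 2 gives the lowest of the three numbers, yet compound 3 and compound 1 both lie within the scatter of it, so no real separation is seen. Compound 4 `O=S(=O)(/C=C/c1ccc(O)c(O)c1)CCCC1CCCC1` differs from compound 2 by cyclopentyl in place of 5-hydroxypentyl on a saturated chain carbon, three bonds along the chain from a sulfonyl sulfur, on a saturated chain carbon, three bonds along the chain from a sulfonyl sulfur. Going by the values given here, the only measured step that bears on this is a 1.3-fold lower number from compound 1 to compound 2 (0.10 log units; within the scatter), where exchanging a chain-end hydroxy for further carbon left the number within the scatter. Trading a hydroxy-bearing chain for a plain carbon ring is therefore expected to move the number little, a 1.0-fold higher number from compound 2 to compound 4 (0.02 log units; within the scatter). Compound 4 is estimated at 7000 nM, between 3500 nM and 14000 nM.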

Compound 4, half-maximal effective concentration: 6300 nM
For compound 4 the middle estimate is 1.1-fold (0.05 log units) above the measured one, and the stated range covers the measured number.
By their numbers in this assay, from the lowest: compounds 4, 2, 3 and 1 (each within the scatter of the next).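

In this assay, cyclopentyl in place of 5-hydroxypentyl, on a saturated chain carbon three bonds along the chain from a sulfonyl sulfur, gives a 1.1-fold lower number from compound 2 to compound 4 (0.03 log units; within the scatter) and so leaves the number within the scatter. The earlier step changed only a carbon eight bonds along the chain, whereas this one shows that a ring of carbon only, with no hydrogen-bond donor or acceptor, can replace the open hydroxylated chain much closer to the sulfur. No measurement available here accounts for this result.

As far as these compounds go, whether an amine or a carboxylic acid on this chain would shift the number stays open. So does whether a cyclohexyl ring would match cyclopentyl.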